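Swapping piperidine for methylpiperazine on the shared core

The compounds below may be only part of what the source reports. "The series", "measured", "known", "first", "only" and "open" are said of these compounds alone.

Measured so far:
Compound 1 `Cn1cnc2c(N3CCCCC3)nc(-c3ccccc3O)nc21`: 30.2%
Compound 2 `CN1CCN(c2nc(-c3ccc(Cl)cc3)nc3[nH]cnc23)CC1`: 6.2%
Compound 3 `Clc1cccc(-c2nc(N3CCCCC3)c3nc[nH]c3n2)c1`: > 80%

Of the compounds shown here, three have been tested in an assay on cells for displacement of a labelled ligand from adenosine receptor A2b (Homo sapiens), read by scintillation counting and radioligand binding, with a stated time of 30 min, tested at 10 uM; on this read-out lower numbers stand for less inhibition and higher numbers for more inhibition at the one concentration tested (going by the name of the read-out). Compound 1 gives 30.2%, the higher of the two plain numbers. Compound 2 gives 6.2%, which lies well beyond the usual scatter below compound 1. Compound 3 does not give a number at all; its result is reported only as a limit of the assay, > 80%, which matches the note that (the limit of > 80% in this assay, at which 1 of the 3 values shown sits).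

Compound 4 `CN1CCN(c2nc(-c3ccccc3O)nc3c2ncn3C)CC1` has not yet been measured. It differs from compound 1 in one place: 4-methylpiperazin-1-yl in place of piperidin-1-yl on an aromatic carbon. Among the measured compounds shown here, with no measured pair differing only in this way, the size of the step has to be guessed from what the two remaining values show. Compound 2 also carries 4-methylpiperazin-1-yl on its core and gives 6.2%, although it differs from compound 4 in more than one place, so it is only a hint.

On that hint, compound 4 is expected to sit lower than compound 1, and the step of a number 18.2 percentage points lower from compound 1 to compound 4 (beyond the scatter) is expected to be a drop beyond the scatter. The estimate for compound 4 in this assay is 12%, somewhere between 0% and 35%.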

Compound 4, a percentage reported as inhibition, at one concentration (the size of the read-out at that concentration, not a potency): 36%
Beside the measured number, compound 4's estimate is 24 percentage points below it, outside the stated range (above it).
By their numbers in this assay, from the lowest: compound 2; then compounds 1 and 4 (each within the scatter of the next). At a limit, above all of these: compound 3.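

In this assay, among the compounds shown here, this pair is the first to differ only in the group on this aromatic carbon, and it gives a number 5.8 percentage points higher from compound 1 to compound 4 (within the scatter). On the core of compound 1, which carries a 2-hydroxyphenyl group, 4-methylpiperazin-1-yl in place of piperidin-1-yl therefore makes no difference that can be told apart from ordinary repeat variation, even though the incoming ring holds a second nitrogen and one more heavy atom. Nothing in the data shown gives a reason for this result.

Going by these compounds, the step describes this one core only, since compound 2 and compound 3 each differ from the other compounds in more than one place, so it remains open whether the same swap would also make no clear difference with a chlorophenyl group on the core and no methyl group on the ring nitrogen. Also open, on these data alone, is what other groups at this position would give, such as a morpholin-4-yl ring, which has oxygen in place of the second nitrogen, or an open-chain amine such as dimethylamino, which has no ring at all.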